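A few compounds are considered here, and "the series" means these few. Any claim that something is new, unique, unknown or untested is made for them only; others in the source may bear on it.

Measured compounds and values:

compound 1, `Oc1nc2nonc2nc1Nc1ccc(SC(F)(F)F)cc1`: 1400 nM
compound 2, `CC(C)(C)c1ccc(Nc2nc3nonc3nc2O)cc1`: 3900 nM
compound 3, `CCCCCCc1ccc(Nc2nc3nonc3nc2O)cc1`: 4700 nM

All three share the same core and differ only in the group on the aromatic ring of the aniline part. In an assay on mitochondria from L6 cells (Rattus norvegicus) for activation, with a stated time of 90 min (a lower number here means that less compound is needed, a higher number that more compound is needed for the effect), compound 3 sits at the top end of the three numbers: compound 2 is within the scatter of it (a 1.2-fold higher number from compound 2 to compound 3 (0.08 log units; within the scatter)), while compound 1 is beyond it (a 3.4-fold higher number from compound 1 to compound 3 (0.53 log units; beyond the scatter)). The step from compound 1 to compound 2 is of the same kind (a 2.8-fold higher number from compound 1 to compound 2 (0.44 log units; beyond the scatter)).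

Compound 4, `Oc1nc2nonc2nc1Nc1ccc(OC(F)(F)Cl)cc1`, is not yet measured. The change from compound 3 is chloro(difluoro)methoxy in place of hexyl on an aromatic carbon. For the measured compounds named here, the steps that bear on it are those from compound 1 to compound 3 and from compound 1 to compound 2: both replace a small halogenated substituent by a larger all-carbon one and both give a modestly higher number in this assay. Compound 4 returns to a halogenated substituent of similar size to that of compound 1, so the reverse of those steps is expected, that is a modestly lower number than compound 3, close to that of compound 1. The expected step is a 2.6-fold lower number from compound 3 to compound 4 (0.42 log units; beyond the scatter). For compound 4 the estimate is 1800 nM, with a range of 800 nM to 4500 nM.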

Compound 4, half-maximal effective concentration: 1900 nM
Beside the measured number, compound 4's estimate is 1.1-fold (0.02 log units) below it; the measured number falls inside the stated range.
By their numbers in this assay, from the lowest: compounds 1 and 4 (each within the scatter of the next); then compounds 2 and 3 (each within the scatter of the next).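

Working from this assay, a halogen-bearing group with an oxygen link at this position stands apart from both all-carbon groups, not only the hexyl chain (a 2.5-fold lower number from compound 3 to compound 4 (0.39 log units; beyond the scatter)) but also the branched tert-butyl group (a 2.1-fold lower number from compound 2 to compound 4 (0.31 log units; beyond the scatter)); both steps are modest but beyond the scatter. Exchanging (trifluoromethyl)sulfanyl for chloro(difluoro)methoxy leaves the number within the scatter (a 1.4-fold higher number from compound 1 to compound 4 (0.13 log units; within the scatter)), so the sulfur-linked and oxygen-linked halogenated groups form one low pair, while tert-butyl and hexyl form one high pair, and none of the four compounds goes against this division. No measurement available here bears on why the four groups divide in this way.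

The compounds shown all carry either a halogenated group linked through sulfur or oxygen or an all-carbon group, so it remains open whether the halogens or the linking atom matter, which a plain methoxy group, a methylsulfanyl group or a single chlorine atom on the same carbon would help to separate. On these data alone, how an amine or a carboxylic acid at this position would read in this assay also remains open.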